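The source may hold more compounds than are shown below. What is called first, only, known or untested is meant among the compounds shown, and "the series" means these compounds.

Working notes on the series. Three compounds sharing one core have numbers in a functional assay on KM12 cells (Homo sapiens) for antiproliferative activity (on this read-out higher numbers stand for weaker inhibition of growth and lower numbers for stronger inhibition of growth), so far. Compound 1 `COc1ccc(-c2nc3cc(F)ccc3s2)cc1C` gives 18600 nM, the second highest of the three numbers. Compound 2 `COc1ccc(-c2nc3cc(F)ccc3s2)c(OC)c1OC` gives 14200 nM, which lies within the scatter of compound 1, so no order is read between these two. Compound 3 `COc1cc(-c2nc3cc(F)ccc3s2)cc(O)c1OC` gives 47500 nM, a higher number than compound 1 and beyond the scatter.

Compound 4 `CCOc1cc(-c2nc3cc(F)ccc3s2)ccc1OC` is still unmeasured. It carries ethoxy in place of methyl on an aromatic carbon of compound 1, ortho to a methoxy group and meta to a large group: ethoxy in place of methyl on an aromatic carbon.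

For the measured compounds named here, no two measured compounds differ in one place only, so the series offers no direct precedent for this step. In this assay the step is expected to stay within the scatter, with no direction favoured. This expectation rests on compound 2, at 14200 nM, which has a different substitution yet stands within the scatter of compound 1. Compound 3 shows that a larger shift cannot be excluded, so the range is kept wide and reaches further upward. The expected change is a 1.1-fold higher number from compound 1 to compound 4 (0.03 log units; within the scatter). For compound 4 the estimated value is 20000 nM, with an expected range from 8000 nM to 50000 nM.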

Compound 4, concentration for 50% growth inhibition: 5420 nM
The estimate for compound 4 lay 3.7-fold (0.57 log units) above the measured number; the whole stated range lies above it.
By their numbers in this assay, from the lowest: compound 4; then compounds 2 and 1 (each within the scatter of the next); then compound 3.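

In this assay, ethoxy in place of methyl on an aromatic carbon, ortho to a methoxy group and meta to a large group, gives a 3.4-fold lower number from compound 1 to compound 4 (0.54 log units; beyond the scatter). For the compounds shown here, this is the first reading of a change at a single place, and it shows that this position is not silent: the larger ethoxy group is accepted here and goes with stronger inhibition of growth. The step brings in an oxygen and extends the group at the same time, so it cannot separate the contribution of the oxygen from that of the added carbon, and nothing measured here gives a reason for the shift.

Open, from the compounds shown here alone, is whether the gain follows the ether oxygen or the size of the group, which a propoxy or isopropoxy group, or a plain ethyl group, at this same carbon would help to decide. Also open, going by these compounds, is whether a longer chain, or an amine or a carboxylic acid at the end of such a chain, would keep, extend or lose the lower number seen with compound 4.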